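Trimethoxy chalcone series: dropping the chloro group

A few compounds are considered here, and "the series" means these few. Any claim that something is new, unique, unknown or untested is made for them only; others in the source may bear on it.

Measured so far in a functional assay on T47D cells (Homo sapiens) for inhibition; a higher number here means a weaker inhibitor of growth, a lower number a stronger inhibitor of growth:
- compound 1, `COc1cc(/C=C/C(=O)c2cccc(-n3cc(-c4ccc(Cl)cc4)[nH]c3=O)c2)cc(OC)c1OC`: 6650 nM
- compound 2, `COc1cc(/C=C/C(=O)c2cccc(-n3cc(-c4ccccc4)[nH]c3=O)c2)ccc1O`: 2700 nM
- compound 3, `O=C(/C=C/c1cccc(O)c1)c1cccc(-n2cc(-c3ccc(Cl)cc3)[nH]c2=O)c1`: 1920 nM

Compound 1 gives the highest number of the three in this assay; compound 2 sits nearer to it, compound 3 furthest away, and both gaps are beyond the usual scatter. No pair of these compounds differs in a single place, so no clean step can be read from the measured set: compound 2 and compound 3 each differ from compound 1 both at the pendant ring and at the cinnamoyl ring.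

Compound 4, `COc1cc(/C=C/C(=O)c2cccc(-n3cc(-c4ccccc4)[nH]c3=O)c2)cc(OC)c1OC`, has not yet been measured. It differs from compound 1 in one place: hydrogen in place of chloro on an aromatic carbon. The same change, taken alone, is not isolated anywhere in the data; compound 2 carries the unsubstituted phenyl but also a different oxygen pattern on the cinnamoyl ring, so its number cannot be assigned to the chloro-to-hydrogen swap.

Given that compound 1 holds the highest number and the two unmatched comparators sit lower, a modest step toward a lower number is expected, of size a 1.7-fold lower number from compound 1 to compound 4 (0.22 log units; within the scatter). For compound 4 the estimated growth-inhibition concentration is 4000 nM, with a range of 1500 nM to 10000 nM.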

Compound 4, concentration for 50% growth inhibition: 2190 nM
Estimate against measurement, compound 4: 1.8-fold (0.26 log units) above; the range from low to high includes it.
By their numbers in this assay, from the lowest: compounds 3, 4 and 2 (each within the scatter of the next); then compound 1.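

In this assay, the change from 4-chlorophenyl to phenyl now stands alone on the trimethoxy cinnamoyl background, with a 3.0-fold lower number from compound 1 to compound 4 (0.48 log units; beyond the scatter), a step beyond the usual scatter. The earlier compounds shown here could not show this, since compound 2 and compound 3 each differ from compound 1 at the cinnamoyl ring as well as at the pendant ring. In this one matched pair, the chloro group on this aromatic carbon goes with the higher number, and the loss of that single heavy atom is enough to shift the growth-inhibition read-out; nothing available explains the shift.

This step rests on a single pair with one cinnamoyl pattern, so whether the same change gives a step of similar size alongside the hydroxy-bearing cinnamoyl rings of compound 2 and compound 3 cannot be read. Also open, on these data alone, is how a fluoro, methyl, methoxy or amino group on the same aromatic carbon would compare with hydrogen and chloro, which would show whether the chloro result reflects something specific to that group or holds for substituents there more generally.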